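The source may hold more compounds than are shown below. What is called first, only, known or untested is meant among the compounds shown, and "the series" means these compounds.

The measured compounds:
Compound 1, `COc1ccc(Sc2cn(-c3ccc4c(c3)B(O)OC4)c3ccccc23)cc1`. In an ADME assay on L929 cells (Mus musculus) for cytotoxicity, read by resazurin assay, with a stated time of 72 h (a lower number here means a stronger inhibitor, a higher number a weaker inhibitor), compound 1 gives > 10 ug/mL, which is a limit of the assay.
Compound 2, `OB1OCc2ccc(-n3cc(Sc4ccc(F)cc4)c4ccccc43)cc21`. In this assay compound 2 gives > 10 ug/mL, again a limit.
Compound 3, `O=C(c1ccccc1)c1ccn(-c2ccc3c(c2)B(O)OC3)c1`. In this assay compound 3 gives > 10 ug/mL, also a limit.

Compound 3 thus stands only at a limit, not at a number. The same holds across the set: the limit of > 10 ug/mL in this assay, at which 3 of the 3 values shown sit. Among the measured compounds shown here, the one step between measured compounds, a step that the two limits leave unreadable from compound 1 to compound 2, is unreadable, since both of its ends are limits. The unmeasured compound 4 is `COc1ccc(C(=O)c2ccn(-c3ccc4c(c3)B(O)OC4)c2)cc1`. It differs from compound 3 by methoxy in place of hydrogen on an aromatic carbon. For the measured compounds named here, no measured step bears directly on this change; the only step available, fluoro in place of methoxy, is unreadable and so gives no size to carry over. With every value shown sitting at the same limit and no readable step, the expectation for a step that the limit leaves unreadable from compound 3 to compound 4 is none beyond the scatter. Compound 4 is therefore expected in this assay at 15 ug/mL, with a range from 5 ug/mL to 50 ug/mL, most likely reported once more as a limit.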

Compound 4, half-maximal inhibitory concentration: > 10 ug/mL
Compound 4: a limit, no number; the forecaster's own chance of this, stated with the estimate: 75%; the middle value is on the limit's open side.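

Compound 3 and compound 4 both sit at a limit rather than at a number, so no step can be read between them in this assay: the limit of > 10 ug/mL in this assay, at which 4 of the 4 values shown sit. The compounds shown leave open where any of their actual values lies, and whether any of these structural changes alters cytotoxicity at all.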